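The source may hold more compounds than are shown below. What is called first, only, known or untested is meant among the compounds shown, and "the series" means these compounds.

Measured so far in a functional assay on SiHa cells (Homo sapiens) for cytotoxicity, read by MTT assay, with a stated time of 48 h; on this read-out higher numbers stand for weaker inhibition and lower numbers for stronger inhibition:
compound 1 `CCCCCCCCNC(=O)[C@@H](NC(=O)c1cccs1)[C@@H](C)O` gives 91900 nM;
compound 2 `CCCCCCCCCCCCNC(=O)[C@@H](NC(=O)c1cccs1)[C@@H](C)O` gives 23900 nM;
compound 3 `CCCCCCCCCCCCCCCCCCNC(=O)[C@@H](NC(=O)c1cccs1)[C@@H](C)O` gives 117000 nM.

Among the compounds with values here, compound 3 has the highest number of the three in this assay; its gap to compound 1 is within the scatter, and only the step of a 4.9-fold higher number from compound 2 to compound 3 (0.69 log units; beyond the scatter) goes beyond it. Compound 4 `C/C=C/C=C/C(=O)N[C@H](C(=O)NCCCCCCCCCCCCCCCCCC)[C@@H](C)O` differs from compound 3 in one place: penta-1,3-dien-1-yl in place of thiophen-2-yl on a carbonyl carbon. The measured steps, a 3.8-fold lower number from compound 1 to compound 2 (0.58 log units; beyond the scatter) and a 1.3-fold higher number from compound 1 to compound 3 (0.10 log units; within the scatter) as well as a 4.9-fold higher number from compound 2 to compound 3 (0.69 log units; beyond the scatter), all concern the length of the saturated chain, and none touches the group on the carbonyl carbon. Within the data shown here, no measured step bears on this change, so no step beyond the scatter is expected in this assay. Compound 4 is therefore estimated at 117000 nM, with a range from 40000 nM to 350000 nM, which means an expected step of no change at the digits printed from compound 3 to compound 4 (within the scatter).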

Compound 4, half-maximal inhibitory concentration: > 200000 nM
Compound 4 gave a limit, no number; the forecaster's own chance of this, stated with the estimate: 15%; at least 1.7-fold (0.23 log units) between middle value and limit.
By their numbers in this assay, from the lowest: compound 2; then compounds 1 and 3 (each within the scatter of the next). At a limit, above all of these: compound 4.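

In this assay compound 4 gives > 200000 nM, which is a limit and not a number. Going by these compounds, putting penta-1,3-dien-1-yl in place of thiophen-2-yl on the carbonyl carbon gives an at least 1.7-fold higher number from compound 3 to compound 4 (0.23 log units; that floor lies within the scatter), and because that floor lies within the scatter, the true size of the step remains unknown. Within the data shown here, this first change away from the chain shows only that the new group brings no stronger inhibition here. On these data alone, whether the same change would act alike with the shorter chain of compound 2 remains open. So does the effect of a phenyl or furan-2-yl group on this carbonyl carbon.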